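Fluoro added to the phenyl of compound 3

The compounds below may be only part of what the source reports. "The series", "measured", "known", "first", "only" and "open" are said of these compounds alone.

Compound 1 `C=C1C[C@]23C[C@@]1(O)CC[C@H]2c1ccc(O)c(C)c1[C@@H]3Cn1cc(-c2ccc(C(F)(F)F)cc2)nn1` gives 12400 nM in a functional assay on MCF7 cells (Homo sapiens) for cytotoxicity, read by MTT assay, with a stated time of 4 days; a higher number here means a weaker inhibitor, a lower number a stronger inhibitor.
Compound 2 `C=C1C[C@]23C[C@@]1(O)CC[C@H]2c1ccc(OS(=O)(=O)c2ccc(C)cc2)c(C)c1[C@@H]3Cn1cc(-c2ccc(F)cc2)nn1` reaches only the limit of this assay, > 20000 nM.
Compound 3 `C=C1C[C@]23C[C@@]1(O)CC[C@H]2c1ccc(O)c(C)c1[C@@H]3Cn1cc(-c2ccccc2)nn1` likewise reaches only the limit, > 20000 nM.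

Compound 3 thus stands at the limit, as does compound 2; only compound 1 carries a number. Compound 4 `C=C1C[C@]23C[C@@]1(O)CC[C@H]2c1ccc(O)c(C)c1[C@@H]3Cn1cc(-c2ccc(F)cc2)nn1` differs from compound 3 by fluoro in place of hydrogen on an aromatic carbon. Among the compounds with values here, the one measured step that bears on this, an at least 1.6-fold higher number from compound 1 to compound 3 (0.20 log units; that floor lies within the scatter), is known only as a floor because the limit of > 20000 nM in this assay, at which 2 of the 3 values shown sit, caps compound 3, and that floor lies within the scatter. A single fluorine is a smaller change than the trifluoromethyl swap, so no step beyond the scatter is expected. Compound 4 is therefore estimated at 18000 nM, with a range of 7000 nM to 50000 nM, and it is expected to be reported again as a limit. The expected step is an at least 1.1-fold lower number from compound 3 to compound 4 (0.04 log units; that floor lies within the scatter).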

Compound 4, half-maximal inhibitory concentration: > 20000 nM
Compound 4: no number, only a limit; the forecaster's own chance of this, stated with the estimate: 60%; at least 1.1-fold (0.04 log units) between middle value and limit.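

Compound 4, which carries 4-fluorophenyl in place of phenyl, gives only a limit in this assay, > 20000 nM, so fluoro at this position does not yield a readable number, and the steps to compound 2 and compound 3 cannot be read. Trifluoromethyl gives an at least 1.6-fold higher number from compound 1 to compound 4 (0.20 log units; that floor lies within the scatter). That step is known only as a floor, which is set by a limit: the limit of > 20000 nM in this assay, at which 3 of the 4 values shown sit.

As far as these compounds go, it stays open whether compound 1 truly differs from compound 4. Also open, from the compounds shown here alone, is how an amine or a carboxylic acid in place of the fluoro would read.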